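A few compounds are considered here, and "the series" means these few. Any claim that something is new, unique, unknown or untested is made for them only; others in the source may bear on it.

Two compounds share one core and differ only at a saturated chain carbon bound to an aromatic carbon and a carbonyl carbon. In a functional assay on CHO cells for antagonist activity at sphingosine 1-phosphate receptor 2 (Homo sapiens), read by calcium flux (a higher number here means a weaker inhibitor, a lower number a stronger inhibitor), compound 1 `CC(C(=O)O)c1nn(Cc2cn3cc(OCC4CC4)c(Cl)cc3n2)c2ccccc2c1=O` gives 6 nM, and compound 2 `O=C(O)Cc1nn(Cc2cn3cc(OCC4CC4)c(Cl)cc3n2)c2ccccc2c1=O` gives 20 nM, the highest of the two numbers. The step of a 3.3-fold higher number from compound 1 to compound 2 (0.52 log units; beyond the scatter) shows that removing the methyl weakened inhibition. Compound 3 `CCC(C(=O)O)c1nn(Cc2cn3cc(OCC4CC4)c(Cl)cc3n2)c2ccccc2c1=O` reverses this direction with a larger group: ethyl in place of hydrogen on a saturated chain carbon bound to an aromatic carbon and a carbonyl carbon. Because a 3.3-fold higher number from compound 1 to compound 2 (0.52 log units; beyond the scatter) was modest yet beyond the scatter, the step of a 2.9-fold lower number from compound 2 to compound 3 (0.46 log units; beyond the scatter) is expected to lower the number. Compound 3 is therefore estimated at 7 nM, with a range of 3 nM to 20 nM.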

Compound 3, half-maximal inhibitory concentration: 5.6 nM
Estimate against measurement, compound 3: 1.3-fold (0.10 log units) above; the measured number falls inside the stated range.
By their numbers in this assay, from the lowest: compounds 3 and 1 (each within the scatter of the next); then compound 2.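

In this assay, ethyl on this saturated chain carbon lowers the number much as methyl does, with a 3.6-fold lower number from compound 2 to compound 3 (0.55 log units; beyond the scatter). Going from methyl to ethyl gives a 1.1-fold lower number from compound 1 to compound 3 (0.03 log units; within the scatter), so the benefit of a group at this carbon persists with the larger one, and compound 1 and compound 3 cannot be told apart. Nothing measured here offers a reason for this. From the compounds shown here alone, whether a longer chain such as propyl, or a ring such as cyclopropyl, would hold the number this low remains open. So does the effect of an amide in place of the carboxylic acid.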